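The compounds below may be only part of what the source reports. "The series", "measured", "known", "first", "only" and "open" are said of these compounds alone.

Compound 1 `COc1cc(-c2ccnc3cc(-c4ccc(C)cc4)nn23)cc(OC)c1OC` gives 3 nM in a functional assay on A549 cells (Homo sapiens) for inhibition, read by CCK-8 assay, with a stated time of 48 h (on this read-out lower numbers stand for stronger inhibition and higher numbers for weaker inhibition), the lowest of the two numbers recorded, with compound 2 `Cn1ccc2cc(-c3cc4nccc(-c5ccc(F)cc5)n4n3)ccc21` giving 3520 nM in this assay. For compound 3 `COc1cc(-c2ccnc3c(-c4ccc(C)cc4)cnn23)cc(OC)c1OC` this assay reports only a limit, > 10000 nM, which is the limit of > 10000 nM in this assay, at which 1 of the 3 values shown sits. Compound 4 `COc1cc(-c2ccnc3cc(-c4ccc5cnn(C)c5c4)nn23)cc(OC)c1OC` differs from compound 1 by 1-methyl-1H-indazol-6-yl in place of 4-methylphenyl on an aromatic carbon. Going by the values given here, no measured pair isolates this change, so the expected step from compound 1 to compound 4 rests on the single anchor alone; the account expects a modest loss, a 3.3-fold higher number from compound 1 to compound 4 (0.52 log units; beyond the scatter), not far beyond the scatter of this assay. Compound 4 is therefore estimated at 10 nM in this assay, within a range from 2 nM to 60 nM.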

Compound 4, half-maximal inhibitory concentration: 233 nM
Beside the measured number, compound 4's estimate is 23-fold (1.37 log units) below it; the measured number lies above the stated range.
By their numbers in this assay, from the lowest: compound 1; then compound 4; then compound 2. At a limit, above all of these: compound 3.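

Going by these compounds alone, this position on the five-membered aromatic ring proves far less forgiving than the earlier compounds could show, since none of them formed a pair differing in one place. In this assay, 1-methyl-1H-indazol-6-yl in place of 4-methylphenyl gives a large loss (a 78-fold higher number from compound 1 to compound 4 (1.89 log units; beyond the scatter)), so the group held here matters strongly to inhibition. Nothing measured here accounts for the size of this step.

Going by these compounds, whether the loss follows the added five-membered ring or its two nitrogens stays open. So does how a 4-chlorophenyl or a 4-aminophenyl would read at this place.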